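A few compounds are considered here, and "the series" means these few. Any claim that something is new, unique, unknown or untested is made for them only; others in the source may bear on it.

Compound 1, `COc1ccc(NC(=O)C(=O)c2cn(C(C)C)c3ccccc23)cn1`: 85 nM
Compound 2, `COc1ccc(NC(=O)C(=O)c2cn(C(C)C)c3cc(Cl)ccc23)cn1`: 1770 nM
Compound 3, `COc1ccc(NC(=O)C(=O)c2cn(C(C)C)c3cccc(OC)c23)cn1`: 7780 nM

In a functional assay on FaDu cells (Homo sapiens) for cytotoxicity, read by MTT assay, with a stated time of 72 h (on this read-out lower numbers stand for higher toxicity in this test and higher numbers for lower toxicity in this test), compound 1 gives the lowest number of the three, the steps of a 21-fold higher number from compound 1 to compound 2 (1.32 log units; beyond the scatter) and a 92-fold higher number from compound 1 to compound 3 (1.96 log units; beyond the scatter) both leading well beyond the scatter. Compound 4, `COCC(C)n1cc(C(=O)C(=O)Nc2ccc(OC)nc2)c2ccccc21`, differs from compound 1 by methoxy in place of hydrogen on a saturated chain carbon, two bonds along the chain from an aromatic nitrogen. Both measured steps changed an aromatic carbon of the shared core, not the chain, so neither bears directly on this change; they show only that the two places tried on the core gave much higher numbers. Within the data shown here, with no step at the chain carbon to lean on, a small shift to a higher number is expected, a 2.4-fold higher number from compound 1 to compound 4 (0.37 log units; beyond the scatter). Compound 4 is therefore estimated at 200 nM, within 50 nM to 900 nM.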

Compound 4, concentration lethal to 50% of the cells in the FaDu assay: 12 nM
Compound 4: middle estimate off by 17-fold (1.22 log units), on the high side; the whole stated range lies above it.
By their numbers in the FaDu assay, from the lowest: compound 4; then compound 1; then compound 2; then compound 3.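

Among these compounds, in the FaDu assay the change from isopropyl to 1-(methoxymethyl)ethyl gives a 7.1-fold lower number from compound 1 to compound 4 (0.85 log units; beyond the scatter), the only step here toward a lower number, whereas both changes on the shared core led to higher numbers. In a physicochemical assay for solubility, read by HPLC (on this read-out higher numbers stand for higher solubility and lower numbers for lower solubility), compound 1 gives 10000 nM and compound 4 gives 10000 nM, the same printed number, so this read-out does not separate the two. Nothing measured here explains the step.

Still open, going by these compounds, is whether the oxygen of the methoxy matters, or whether a hydroxyl, an amine or a plain ethyl at this chain carbon would give a similar number.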